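Fluorophenyl position scan across the shared core

The compounds below may be only part of what the source reports. "The series", "measured", "known", "first", "only" and "open" are said of these compounds alone.

Measured so far:
compound 1, `Oc1cccc(-c2cc(-c3ccc(F)cc3)cc(-c3ccccc3O)n2)c1`: in a functional assay on HCT-15 cells (Homo sapiens) for inhibition (a higher number here means a weaker inhibitor, a lower number a stronger inhibitor), compound 1 gives > 50000 nM, a limit of the assay.
compound 2, `Oc1cccc(-c2cc(-c3ccccc3F)cc(-c3cccc(O)c3)n2)c1`: compound 2 gives 5300 nM.
compound 3, `Oc1cccc(-c2cc(-c3cccc(F)c3)cc(-c3cccc(O)c3)n2)c1`: compound 3 gives 7860 nM.

Compound 3 holds the highest of the two numbers; its nearest neighbour is compound 2, and the step of a 1.5-fold higher number from compound 2 to compound 3 (0.17 log units; within the scatter) lies within the scatter. Compound 4, `Oc1cccc(-c2cc(-c3ccc(F)cc3)cc(-c3cccc(O)c3)n2)c1`, differs from compound 3 by 4-fluorophenyl in place of 3-fluorophenyl on an aromatic carbon. Within the data shown here, the one measured step that moves the fluorine around its ring, a 1.5-fold higher number from compound 2 to compound 3 (0.17 log units; within the scatter), stays within the scatter, so no step beyond the scatter is expected here either. Compound 1 also carries a 4-fluorophenyl group, with a different hydroxyphenyl group, and its value is a limit (the limit of > 50000 nM in this assay, at which 1 of the 3 values shown sits). Compound 4 is therefore expected to give about 8500 nM, between 3500 nM and 22000 nM. The expected step is a 1.1-fold higher number from compound 3 to compound 4 (0.03 log units; within the scatter).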

Compound 4, half-maximal inhibitory concentration: 6310 nM
Compound 4: the middle estimate sits 1.3-fold (0.13 log units) above what was measured; measured number inside the range.
By their numbers in this assay, from the lowest: compounds 2, 4 and 3 (each within the scatter of the next). At a limit, above all of these: compound 1.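

With the 4-fluorophenyl group in place, the three fluorine positions on this ring cannot be told apart: a 1.2-fold lower number from compound 3 to compound 4 (0.10 log units; within the scatter), and a 1.2-fold higher number from compound 2 to compound 4 (0.08 log units; within the scatter). Among these compounds, the only change here that goes beyond the scatter lies on the other ring, 3-hydroxyphenyl in place of 2-hydroxyphenyl: an at least 7.9-fold lower number from compound 1 to compound 4 (0.89 log units; beyond the scatter). Compound 1 stands at a limit, so the size of that step is a bound only: the limit of > 50000 nM in this assay, at which 1 of the 4 values shown sits.

As far as these compounds go, whether an amine or a carboxylic acid in place of the fluorine moves the number beyond the scatter stays open. So does how the shared core behaves with a 4-hydroxyphenyl group.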